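Furan Isomers on a Nucleoside Core and Cell Growth

The source may hold more compounds than are shown below. What is called first, only, known or untested is meant among the compounds shown, and "the series" means these compounds.

compound 1 `O=c1[nH]cnc2c1c(-c1ccoc1)cn2[C@@H]1O[C@H](CO)[C@@H](O)[C@H]1O`: 12100 nM
compound 2 `O=c1[nH]cnc2c1c(-c1ccco1)cn2[C@@H]1O[C@H](CO)[C@@H](O)[C@H]1O`: > 15000 nM
compound 3 `COc1nc(N)nc2c1c(-c1ccoc1)cn2[C@@H]1O[C@H](CO)[C@@H](O)[C@H]1O`: > 20000 nM

All three were tested in a functional assay on HepG2 cells (Homo sapiens) for antiproliferative activity, read by XTT assay, with a stated time of 72 h; on this read-out lower numbers stand for stronger inhibition and higher numbers for weaker inhibition. Compound 1 gives a measured number, 12100 nM. For compound 2 the assay reports only a limit, not a number: > 15000 nM. That value for compound 2 is the limit of > 15000 nM in this assay, at which 1 of the 3 values shown sits. For compound 3 the assay likewise reports only a limit: > 20000 nM. That value for compound 3 is the limit of > 20000 nM in this assay, at which 1 of the 3 values shown sits.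

Compound 1 and compound 2 differ in a single place, (furan-2-yl in place of furan-3-yl on an aromatic carbon). The step in this assay was an at least 1.2-fold higher number from compound 1 to compound 2 (0.09 log units; that floor lies within the scatter). How the core of compound 3 differs from the core of compound 1 is not broken down here.

Compound 4, `COc1nc(N)nc2c1c(-c1ccco1)cn2[C@@H]1O[C@H](CO)[C@@H](O)[C@H]1O`, has not yet been measured in this assay. It carries the same change relative to compound 3, (furan-2-yl in place of furan-3-yl on an aromatic carbon), and the place described for both changes reads the same, so it is the same change.

Compound 3 already sits at a limit, and the earlier step ran toward a higher number, so compound 4 is expected to give at best a similar step, a step that the limit leaves unreadable from compound 3 to compound 4. The estimate for compound 4 is 30000 nM, within 15000 nM to 80000 nM, and most likely the assay again reports only a limit.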

Compound 4, half-maximal inhibitory concentration: > 20000 nM
Compound 4 was reported as a limit; the forecaster's own chance of this, stated with the estimate: 85%; the middle value lies beyond the limit too.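

In this assay compound 4 gives only a limit, > 20000 nM, and compound 3 also gives only a limit, so the step between these two compounds cannot be read. The compounds shown leave open whether furan-2-yl in place of furan-3-yl changes the read-out at all on the core of compound 3.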